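Removing a Methyl from a Triazene Amine Nitrogen

The source may report more compounds than this note shows. Statements on the series, on what has been measured and on what is new or still open speak of the compounds shown alone.

Measured so far in an ADME assay on MT4 cells (Homo sapiens) for cytotoxicity, read by MTT assay, with a stated time of 96 h; a higher number here means that more compound is tolerated, a lower number that less compound is tolerated:
- compound 1, `c1ccc(/N=N/c2ccc(NC[C@@H]3CCCN4CCCC[C@H]34)c3c2CCCC3)cc1`, gives 100000 nM
- compound 2, `CN(C)CCCN(/N=N/c1cc(F)ccc1F)c1ccccc1`, gives 13000 nM
- compound 3, `CN(Cc1ccccc1)/N=N/c1ccccc1`, gives >= 100000 nM

Compound 3 does not have a true number in this assay; its value is a limit of the assay, meaning the cells tolerated it up to the highest concentration tested. This is the situation described by the limit of >= 100000 nM in this assay, at which 1 of the 3 values shown sits. Among the measured compounds shown here, compound 1 sits at the same concentration, while compound 2 is the one compound of the three whose toxicity was reached at a lower concentration.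

Compound 4, `c1ccc(CN/N=N/c2ccccc2)cc1`, is not yet measured. It differs from compound 3 by a single small change: hydrogen in place of methyl on an amine nitrogen. For the measured compounds named here, no step between two measured compounds matches this change, so there is no direct guide to its effect. Since compound 3 sits at the limit, the step from compound 3 to compound 4 is expected to be none beyond the usual scatter, a number no higher from compound 3 to compound 4 (the limit leaves the size open). Compound 4 is therefore expected to give about 100000 nM, somewhere between 25000 nM and 400000 nM, and quite possibly again only a limit.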

Compound 4, half-maximal cytotoxic concentration: 42000 nM
For compound 4 the middle estimate is 2.4-fold (0.38 log units) above the measured one, within the range that was stated.
By their numbers in this assay, from the lowest: compound 2; then compound 4; then compound 1.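

In this assay, hydrogen in place of methyl on an amine nitrogen gives an at least 2.3-fold lower number from compound 3 to compound 4 (0.37 log units; beyond the scatter), the only step shown at this position. The removal of this single carbon is therefore enough to bring the cytotoxicity of this compound pair into a range that can be read, and compound 4 gives a true number of 42000 nM. Going by these compounds, the full size of the step stays unknown because compound 3 gives only a limit: the limit of >= 100000 nM in this assay, at which 1 of the 4 values shown sits.

On these data alone, how an ethyl, a longer chain or a hydroxyethyl group on this same nitrogen would compare remains open, as does whether the same change would give a similar step in compounds with other groups on the benzyl or phenyl rings. The compounds shown also leave open why the number falls, since nothing here points to a cause.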